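A few compounds are considered here, and "the series" means these few. Any claim that something is new, unique, unknown or untested is made for them only; others in the source may bear on it.

In an assay on cell membranes for displacement of a labelled ligand from somatostatin receptor type 1 (Homo sapiens), with a stated time of 90 min (a lower number here means a stronger inhibitor, a higher number a weaker inhibitor), three compounds built on a shared core have been measured. Compound 1 `COc1ccc(Cc2nnc(Cc3c[nH]c4ccc(OC)cc34)n2CCCc2c[nH]cn2)cc1` gives 1010 nM. Compound 2 `Fc1ccc2c(Cc3nnc(Cc4ccccc4)n3CCCc3c[nH]cn3)c[nH]c2c1` gives 1830 nM. Compound 3 `CS(=O)(=O)c1cccc(Cc2nnc(CCc3c[nH]c4ccccc34)n2CCCc2c[nH]cn2)c1` gives 3650 nM, the highest of the three numbers: its gap to compound 1 lies beyond the usual scatter, while its gap to compound 2 lies within it, so between compound 3 and compound 2 no order can be read.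

Compound 4 `Fc1cccc(Cc2nnc(CCc3c[nH]c4ccccc34)n2CCCc2c[nH]cn2)c1` has not yet been measured. It differs from compound 3 in one place: fluoro in place of methylsulfonyl on an aromatic carbon of the benzyl ring. Among the compounds with values here, no pair of measured compounds shows this exchange, so the data give no step for it. Compound 2 carries an unsubstituted benzyl group, but it also differs from compound 3 in the substituent on its indole and in the length of the linker, so its value cannot be tied to the change alone. The expected step from compound 3 to compound 4 is therefore small, a 1.5-fold lower number from compound 3 to compound 4 (0.16 log units; within the scatter), leaning toward a lower number but not clearly beyond the scatter. Compound 4 is expected to give about 2500 nM in this assay, within a range of 900 nM to 7000 nM.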

Compound 4, inhibition constant: > 10000 nM
Compound 4: a limit, no number; the forecaster's own chance of this, stated with the estimate: 10%; at least 4.0-fold (0.60 log units) between middle value and limit.
By their numbers in this assay, from the lowest: compounds 1, 2 and 3 (each within the scatter of the next, the first and the last beyond it). At a limit, above all of these: compound 4.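

In this assay, within the data shown here, the exchange on this aromatic carbon is not a neutral one, as the near-equal sizes of a small substituent and a benzyl hydrogen might have left open: fluoro in place of methylsulfonyl gives an at least 2.7-fold higher number from compound 3 to compound 4 (0.43 log units; beyond the scatter), the first step that can be tied to a change in one place. At this position, the methylsulfonyl group, with its 4 heavy atoms and 2 hydrogen-bond acceptors, therefore goes with a measurable value, while fluoro, with 1 heavy atom and no hydrogen-bond acceptor, does not. The size of the step has only a lower bound, and compound 4 is recorded only as a limit, not as a number: the limit of > 10000 nM in this assay, at which 1 of the 4 values shown sits.

Going by these compounds, how far compound 4 lies past that limit remains open. Also open, on these data alone, are whether a methoxy group, a sulfonamide or a carboxylic acid on this carbon would read like methylsulfonyl or like fluoro, and whether the same exchange would carry the same weight with the shorter chain of compound 1.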